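Aryl sulfonate ureas on M21 cells: hydroxyphenyl swap

The compounds below may be only part of what the source reports. "The series", "measured", "known", "first", "only" and "open" are said of these compounds alone.

Compound 1 `CCc1ccccc1OS(=O)(=O)c1ccc(NC(=O)NCCCCl)cc1` gives 15000 nM in a functional assay on M21 cells (Homo sapiens) for cytotoxicity, read by sulforhodamine B assay, with a stated time of 48 h; a lower number here means a stronger inhibitor, a higher number a weaker inhibitor. Compound 2 `O=C(NCCCCl)Nc1ccc(S(=O)(=O)Oc2ccc(O)cc2)cc1` differs from compound 1 by 4-hydroxyphenyl in place of 2-ethylphenyl on an oxygen and in this assay compound 2 gives 47000 nM; the step is a 3.1-fold higher number from compound 1 to compound 2 (0.50 log units; beyond the scatter). Compound 3 `CCNC(=O)Nc1cccc(S(=O)(=O)Oc2ccccc2CC)c1` rests on a different core; the difference between the core of compound 1 and the core of compound 3 is not broken down here. In this assay compound 3 gives 30000 nM. Compound 4 `CCNC(=O)Nc1cccc(S(=O)(=O)Oc2ccc(O)cc2)c1` is not yet measured and differs from compound 3 by 4-hydroxyphenyl in place of 2-ethylphenyl on an oxygen, the same change that separates compound 1 and compound 2. Because a 3.1-fold higher number from compound 1 to compound 2 (0.50 log units; beyond the scatter) was measured for that change, a step of similar size is expected for compound 4, a 2.8-fold higher number from compound 3 to compound 4 (0.45 log units; beyond the scatter), though one prior example is a thin basis. Compound 4 is expected to give 85000 nM, within a range from 35000 nM to 200000 nM.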

Compound 4, half-maximal inhibitory concentration: 42000 nM
The estimate for compound 4 lay 2.0-fold (0.31 log units) above the measured number; the measured number falls inside the stated range.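

In this assay, 4-hydroxyphenyl in place of 2-ethylphenyl on the oxygen bound to the sulfonyl sulfur gives a 1.4-fold higher number from compound 3 to compound 4 (0.15 log units; within the scatter), so on this core the change stands within the scatter. Set beside the step on the other core, the two readings do not separate, and the change carries over as far as two cores can show: the same change on two cores in this assay, a 3.1-fold higher number (0.50 log units; beyond the scatter) from compound 1 to compound 2 and a 1.4-fold higher number (0.15 log units; within the scatter) from compound 3 to compound 4, 2.2-fold (0.35 log units) apart, within the scatter of two such steps. This does not show that the step has the same size on both cores, and two pairs set no rule for the series.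

Open, going by these compounds, is how the step behaves when the phenyl on that oxygen carries an amine or a carboxylic acid. Also open, on these data alone, is whether a longer chain on the urea alters it.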